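The source may report more compounds than this note shows. Statements on the series, on what has been measured and on what is new or still open speak of the compounds shown alone.

Compound 1 `COc1cc2ncnc(-n3nc(-c4cccnc4)nc3N)c2cc1OC`: > 71000 nM (a limit)
Compound 2 `COc1cc2nc(-c3ccccc3)nc(-n3nc(-c4ccccn4)nc3N)c2cc1OC`: > 27000 nM (a limit)
Compound 3 `COc1cc2ncnc(-n3nc(-c4ccccn4)nc3N)c2cc1OCCCNC(=O)OC(C)(C)C`: > 12000 nM (a limit)

These three results come from an ADME assay on BJ cells (Homo sapiens) for cytotoxicity, with a stated time of 72 h; on this read-out higher numbers stand for an effect only at larger amounts of compound and lower numbers for an effect already at smaller amounts. None of them is an exact number, so the compounds cannot be ranked against one another. Compound 3 is known only through its limit of > 12000 nM. For the measured compounds named here, compounds 1 and 2 likewise give only limits, so no measured step is available as a guide.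

Compound 4 `COc1cc2ncnc(-n3nc(-c4ccccn4)nc3N)c2cc1OCCCNC(=O)C(F)(F)F` differs from compound 3 in a single place: trifluoromethyl in place of tert-butoxy on a carbonyl carbon. Trifluoromethyl stands in place of tert-butoxy on a carbonyl carbon, and the rest of the structure is unchanged.

With no exact value in this series, no clear move in either direction can be predicted in this assay. The expected step, a step that the limit leaves unreadable from compound 3 to compound 4, is no larger than the usual scatter. Compound 4 may well return only a limit too. For compound 4 the estimated value is 20000 nM, with an expected range from 8000 nM to 70000 nM.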

Compound 4, half-maximal effective concentration: > 7000 nM
Compound 4 was reported as a limit (the forecaster's own chance of this, stated with the estimate: 75%); the middle value does not contradict the limit.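

In this assay, compound 3 and compound 4 are both reported only as limits, so the step between them cannot be read. The compounds shown leave open at what concentration any of them would show an effect, and whether trifluoromethyl in place of tert-butoxy shifts it.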